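A few compounds are considered here, and "the series" means these few. Any claim that something is new, unique, unknown or untested is made for them only; others in the source may bear on it.

In a functional assay on MKN-28 cells (Homo sapiens) for cytotoxicity, read by MTT assay (on this read-out higher numbers stand for weaker inhibition and lower numbers for stronger inhibition), compound 1 `C=C1C(=O)[C@]23C[C@@]1(O)CC[C@H]2[C@@]12C=CC(=O)[C@](C)(C(=O)O1)[C@H]2[C@@H]3C(=O)OC`, with hydroxy on a saturated ring carbon of the shared core, gives 39600 nM. Compound 2 `C=C1C(=O)[C@]23C[C@@]1(I)CC[C@H]2[C@@]12C=CC(=O)[C@](C)(C(=O)O1)[C@H]2[C@@H]3C(=O)OC`, with iodo on that carbon, gives 6700 nM. Compound 3 `C=C1C(=O)[C@]23C[C@@]1(OCC)CC[C@H]2[C@@]12C=CC(=O)[C@](C)(C(=O)O1)[C@H]2[C@@H]3C(=O)OC`, with ethoxy there, gives 82700 nM, the highest number of the three and so the weakest inhibition so far.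

Compound 4 `C=C1C(=O)[C@]23C[C@@]1(OC)CC[C@H]2[C@@]12C=CC(=O)[C@](C)(C(=O)O1)[C@H]2[C@@H]3C(=O)OC` is not yet measured and carries methoxy in place of the ethoxy of compound 3: hydrogen in place of methyl on a saturated chain carbon bound to an oxygen on a saturated carbon.

The most relevant evidence is a 2.1-fold higher number from compound 1 to compound 3 (0.32 log units; beyond the scatter), a modest step when ethyl replaces hydrogen on that oxygen. The large 12-fold higher number from compound 2 to compound 3 (1.09 log units; beyond the scatter) swaps iodo for ethoxy, a different kind of change, and says little here. Methyl on the oxygen is a smaller change from hydroxy than ethyl, so the expected result is only a small move towards compound 1. The expected step is a 1.5-fold lower number from compound 3 to compound 4 (0.18 log units; within the scatter), probably not beyond the scatter. For compound 4 the estimated value is 55000 nM, with an expected range of 27000 nM to 110000 nM.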

Compound 4, half-maximal inhibitory concentration: 3400 nM
Estimate against measurement, compound 4: 16-fold (1.21 log units) above; the whole stated range lies above it.
By their numbers in this assay, from the lowest: compounds 4 and 2 (each within the scatter of the next); then compound 1; then compound 3.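

In this assay, this position proves highly sensitive to the group on the oxygen: trimming ethoxy to methoxy gives a 24-fold lower number from compound 3 to compound 4 (1.39 log units; beyond the scatter), while putting methyl on the oxygen of the hydroxy group gives a 12-fold lower number from compound 1 to compound 4 (1.07 log units; beyond the scatter), so the ethyl step alone gave no hint of what methyl would do. Methoxy also matches iodo in this test, with a 2.0-fold lower number from compound 2 to compound 4 (0.29 log units; within the scatter), a gap that stays within the usual scatter. Nothing measured here bears on why a single extra methyl separates methoxy so sharply from ethoxy.

As far as these compounds go, whether a propoxy chain on that oxygen would behave like ethoxy, and what an amine on the same carbon would give, remains open. Whether the sharp gap between methoxy and ethoxy also appears in other cell lines is open too.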